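The source may report more compounds than this note shows. Statements on the series, on what has been measured and on what is new or still open speak of the compounds shown alone.

Compound 1 `C=C1CC[C@H]2C(C)(C)CCC[C@]2(C)[C@H]1C/C=C1\CC(OC)OC1=O`: 101%
Compound 2 `C=C1CC[C@H]2C(C)(C)CCC[C@]2(C)[C@H]1C/C=C1\C=COC1=O`: 99%

In a functional assay on RAW264.7 cells (Mus musculus) for inhibition, read by ELISA, with stated times of 1 h and 18 h, tested at 0.1 uM (on this read-out lower numbers stand for a stronger effect and higher numbers for a weaker effect at the one concentration tested), compound 2 gives 99%, the lower of the two numbers shown, while compound 1 gives 101%; the two lie within the scatter of each other, so neither can be called the stronger. Both leave the read-out essentially untouched at the single concentration tested. Compound 3 `C=C1CC[C@H]2C(C)(C)CCC[C@]2(C)[C@H]1CC=O` differs from compound 2 in one place: a group of 2 heavy atoms (1 carbon, 1 oxygen; no ring) in place of a group of 7 heavy atoms (5 carbon, 2 oxygen; one five-membered non-aromatic ring with 1 hetero atom), on a saturated chain carbon bound to a saturated ring carbon. For the measured compounds named here, no step between measured compounds of this kind is known, so no change beyond the scatter is expected in this assay. Compound 3 is therefore estimated to give 98%, ranging from 85% to 110%. The step of a number 1 percentage points lower from compound 2 to compound 3 (within the scatter) is expected to stay within the scatter.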

Compound 3, a percentage reported as activity, at one concentration (the size of the read-out at that concentration, not a potency): 100%
Estimate against measurement, compound 3: 2 percentage points below; measured number inside the range.
By their numbers in this assay, from the lowest: compounds 2, 3 and 1 (each within the scatter of the next).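

In this assay the exchange of the group holding the five-membered non-aromatic ring for formyl, on a saturated chain carbon bound to a saturated ring carbon, gives a number 1 percentage points higher from compound 2 to compound 3 (within the scatter) and so leaves the read-out where it was. The ring is therefore not what separates these compounds here, since even this much smaller group reads the same at the one concentration tested. No measurement at hand bears on why this is so. Whether an amine, a carboxylic acid or a longer chain at this place would shift the read-out stays open, as does the behaviour of these compounds at other concentrations.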